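A few compounds are considered here, and "the series" means these few. Any claim that something is new, unique, unknown or untested is made for them only; others in the source may bear on it.

Compound 2 `Cc1nn(C)c2c1C(c1cccc(Cl)c1)=NCCN2CCCN(C)C` carries the shared core of compound 1 `Cc1nn(C)c2c1C(c1cccc(Cl)c1)=NCCN2` with a 3-(dimethylamino)propyl group in place of hydrogen on a nitrogen on an aromatic ring in a ring. In a functional assay on the whole organism for positive allosteric modulation, with Rattus norvegicus as the target (on this read-out lower numbers stand for an effect already at smaller amounts and higher numbers for an effect only at larger amounts of compound), compound 1 gives 0.63 mg/kg. For compound 2 this assay reports only a limit, > 10 mg/kg. Going by the values given here, the one measured step, an at least 15-fold higher number from compound 1 to compound 2 (1.20 log units; beyond the scatter), is bounded by the limit of > 10 mg/kg in this assay, at which 1 of the 2 values shown sits, so its true size is not known. Compound 3 `Cc1nn(C)c2c1C(c1ccccc1Cl)=NCCN2CCCN(C)C` differs from compound 2 by 2-chlorophenyl in place of 3-chlorophenyl on a carbon with a double bond to nitrogen. Among the compounds with values here, no measured step concerns a change of this kind, so the data give no basis for a direction or size of effect beyond the scatter. Compound 2 stands at a limit, and that is the only fixed point here. Compound 3 is therefore expected to remain near that limit, with a step that the limit leaves unreadable from compound 2 to compound 3 expected to be small. For compound 3 the estimate is 15 mg/kg, from 5 mg/kg to 45 mg/kg.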

Compound 3, minimum effective dose: > 10 mg/kg
Compound 3 gave a limit, no number; the forecaster's own chance of this, stated with the estimate: 75%; the middle value does not contradict the limit.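

Going by these compounds alone, compound 2 and compound 3 both stand at a limit in this assay, so no step between them can be read: the limit of > 10 mg/kg in this assay, at which 2 of the 3 values shown sit. The compounds shown leave open whether 2-chlorophenyl in place of 3-chlorophenyl changes the minimum effective dose at all, and in which direction.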